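Adding a Second Fluoro to the Aryl Imine

The source may hold more compounds than are shown below. What is called first, only, known or untested is meant among the compounds shown, and "the series" means these compounds.

Two compounds have been measured in a functional assay on NIH3T3 cells (Mus musculus) for antiproliferative activity; a higher number here means a weaker inhibitor, a lower number a stronger inhibitor:

compound 1 `Cc1nc2c([nH]1)C(=O)/C(=N/c1ccc(F)cc1)C(Cl)=C2O`: 1200 nM
compound 2 `Cc1nc2c([nH]1)C(=O)/C(=N/c1cccc(Cl)c1)C(Cl)=C2O`: 1600 nM

Going by the values given here, of these two numbers, the one for compound 1 is the smaller, but the step of a 1.3-fold higher number from compound 1 to compound 2 (0.12 log units; within the scatter) lies within the scatter, so neither compound can be called the stronger inhibitor.

Compound 3 `Cc1nc2c([nH]1)C(=O)/C(=N/c1ccc(F)cc1F)C(Cl)=C2O` differs from compound 1 in one place: fluoro in place of hydrogen on an aromatic carbon. Among the compounds with values here, no measured pair shows this kind of change, a fluoro entering where a hydrogen stood. Within the data shown here, the only measured step, a 1.3-fold higher number from compound 1 to compound 2 (0.12 log units; within the scatter), exchanges the whole aryl group on the double-bonded nitrogen and still stays within the scatter, which suggests that the aryl group tolerates variation without a clear effect in this assay.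

For compound 3, therefore, no step beyond the scatter is expected, and the expected step is a 1.1-fold higher number from compound 1 to compound 3 (0.03 log units; within the scatter). Compound 3 is estimated at 1300 nM, with a range from 500 nM to 3500 nM.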

Compound 3, half-maximal inhibitory concentration: 800 nM
Compound 3: middle estimate off by 1.6-fold (0.21 log units), on the high side; the measured number falls inside the stated range.
By their numbers in this assay, from the lowest: compounds 3, 1 and 2 (each within the scatter of the next).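

Going by these compounds alone, this pair is the first to show a fluoro taking the place of a hydrogen on the aryl group, on an aromatic carbon ortho to a large group and meta to a fluoro group. In this assay the change gives a 1.5-fold lower number from compound 1 to compound 3 (0.18 log units; within the scatter) and so shows that this position accepts the added fluoro, with no difference in strength that can be told apart from ordinary repeat variation. Nothing at hand explains the result in terms of how the fluoro acts at this place.

Still open, on these data alone, is whether a larger or charged group, such as a methoxy group, an amine or a carboxylic acid, would be accepted on this same aromatic carbon. Also open, as far as these compounds go, is whether any change here can move the number beyond the scatter.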